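Cyano in Place of Acetyl on the Sulfonyl Vinyl Carbon

A few compounds are considered here, and "the series" means these few. Any claim that something is new, unique, unknown or untested is made for them only; others in the source may bear on it.

Measured so far:
compound 1, `N#C/C(=C\c1c(-c2ccccc2)[nH]c2ccccc12)C(N)=O`: 6000 nM
compound 2, `O=C(/C(=C\c1c(-c2ccccc2)[nH]c2ccccc12)S(=O)(=O)c1ccccc1)c1ccccc1`: 3000 nM
compound 3, `CC(=O)/C(=C\c1c(-c2ccccc2)[nH]c2ccccc12)S(=O)(=O)c1ccccc1`: 400 nM

In a functional assay on MT4 cells (Homo sapiens) for antiproliferative activity, read by MTT assay, with a stated time of 96 h (a higher number here means that more compound is needed for the effect, a lower number that less compound is needed), compound 3 gives 400 nM, the lowest of the three numbers; its nearest neighbour is compound 2 with 3000 nM, and compound 1, furthest away, gives 6000 nM. Compound 4, `N#C/C(=C\c1c(-c2ccccc2)[nH]c2ccccc12)S(=O)(=O)c1ccccc1`, is not yet measured. It differs from compound 3 in one place: cyano in place of acetyl on a double-bonded chain carbon bound to a double-bonded chain carbon and a sulfonyl sulfur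

Going by the values given here, only one measured step concerns the same double-bonded chain carbon, a 7.5-fold lower number from compound 2 to compound 3 (0.88 log units; beyond the scatter), and it swaps groups on the carbonyl carbon rather than exchanging the acetyl itself, so it does not bear directly on this change. Among the compounds with values here, the only measured compound carrying a cyano group, compound 1, gives 6000 nM, but its other substituent is an amide and not a phenylsulfonyl, so no single step separates it from compound 4. Within the data shown here, with no direct precedent, the account expects compound 4 to need somewhat more compound than compound 3, a step of a 3.8-fold higher number from compound 3 to compound 4 (0.57 log units; beyond the scatter) upward, with wide uncertainty. The estimate for compound 4 in this assay is 1500 nM, between 400 nM and 6000 nM.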

Compound 4, half-maximal effective concentration: 400 nM
Compound 4: middle estimate off by 3.8-fold (0.57 log units), on the high side; the measured number falls inside the stated range.
By their numbers in this assay, from the lowest: compounds 3 and 4 (each within the scatter of the next); then compounds 2 and 1 (each within the scatter of the next).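

In this assay, the exchange of acetyl for cyano on the double-bonded chain carbon bound to a double-bonded chain carbon and a sulfonyl sulfur gives no change at the digits printed from compound 3 to compound 4 (within the scatter), so with phenylsulfonyl in place, these two groups cannot be told apart at this position. Benzoyl at the same carbon does separate from them: cyano in its place gives a 7.5-fold lower number from compound 2 to compound 4 (0.88 log units; beyond the scatter), which matches the step with methyl in place of phenyl on the carbonyl carbon, a 7.5-fold lower number from compound 2 to compound 3 (0.88 log units; beyond the scatter), and so it is benzoyl that stands out among the three groups. With cyano held constant, phenylsulfonyl in place of carbamoyl gives a 15-fold lower number from compound 1 to compound 4 (1.18 log units; beyond the scatter), the largest step in this set and the first to isolate the sulfonyl side of the double-bonded carbon; no measurement shown accounts for any of these steps.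

The compounds shown leave open whether other groups on this carbon, such as a carboxylic acid or a methyl ester, would also stand level with cyano and acetyl. They also leave open whether the result would hold with methyl in place of the phenyl on the sulfonyl sulfur.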